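From fluoro to trifluoromethyl: a cytotoxicity estimate for compound 3

The compounds below may be only part of what the source reports. "The series", "measured", "known", "first", "only" and "open" are said of these compounds alone.

- Compound 1 `COc1ccc(NC(=O)CSc2nc(Nc3c(C)cc(/C=C/C#N)cc3C)c3cc(OC)c(OC)cc3n2)cc1` gives > 225000 nM as a limit, not a number
- Compound 2 `COc1cc2nc([S+]([O-])CC(=O)Nc3ccc(F)cc3)nc(Nc3c(C)cc(/C=C/C#N)cc3C)c2cc1OC` gives 27400 nM as a measured number

For the measured compounds named here, in an ADME assay on MT4 cells (Homo sapiens) for cytotoxicity, read by MTT assay, with a stated time of 5 days (on this read-out lower numbers stand for higher toxicity in this test and higher numbers for lower toxicity in this test), compound 2, at 27400 nM as the only actual number so far, is the sole fixed point. Compound 1 at > 225000 nM is a limit and no number.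

Compound 3 `COc1cc2nc([S+]([O-])CC(=O)Nc3ccc(C(F)(F)F)cc3)nc(Nc3c(C)cc(/C=C/C#N)cc3C)c2cc1OC` replaces the fluoro of compound 2 with trifluoromethyl on an aromatic carbon, para to a large group (trifluoromethyl in place of fluoro on an aromatic carbon). Going by the values given here, no two measured compounds differ in one place alone, so no measured step guides this change. The expectation therefore rests on compound 2 at 27400 nM and foresees no shift beyond the usual scatter in this assay for this swap. The expected step is a 1.1-fold lower number from compound 2 to compound 3 (0.04 log units; within the scatter) and stays small. A report as a bare limit remains possible for compound 3. For compound 3 the estimated value is 25000 nM with an expected range from 8000 nM to 80000 nM in this test.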

Compound 3, half-maximal cytotoxic concentration: 52200 nM
Compound 3: middle estimate off by 2.1-fold (0.32 log units), on the low side; low and high end bracket the measured number.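

With compound 3, this series gains its first change made in one place alone: in this assay, trifluoromethyl in place of fluoro gives a 1.9-fold higher number from compound 2 to compound 3 (0.28 log units; within the scatter). This aromatic carbon, para to a large group, can therefore carry a group of four heavy atoms instead of a single one without a shift that stands out from the scatter of this test. Compound 2 and compound 3 both give actual numbers, which makes this step readable, whereas only compound 1 sits at the limit of the test: the limit of > 225000 nM in this assay, at which 1 of the 3 values shown sits.

Going by these compounds, whether an amine or a carboxylic acid on the same carbon would behave as quietly remains open, as one swap says little about other groups. Compound 1 differs from compound 2 and compound 3 in more than one place, so its limit cannot be tied to any single change.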